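The source may hold more compounds than are shown below. What is called first, only, known or untested is meant among the compounds shown, and "the series" means these compounds.

In a functional assay on ileum (Cavia porcellus) for antagonist activity (on this read-out lower numbers stand for stronger inhibition and higher numbers for weaker inhibition), compound 3 `CC(=O)c1ccc(OCCCOc2ccc3c(O)c([N+](=O)[O-])c(=O)oc3c2)cc1` gives 6100 nM, the higher of the two actual numbers in this small set, while compound 1 `CCCc1c(OCCCOc2ccccc2)ccc2c(O)c([N+](=O)[O-])c(=O)oc12` gives 540 nM, a gap that lies beyond the scatter. Compound 2 `COc1ccc(OCCCOc2ccc3c(O)c([N+](=O)[O-])c(=O)oc3c2)cc1` reads > 4000 nM, which is a limit of the assay and not a number.

The next compound in view is compound 4 `COC(=O)c1ccc(OCCCOc2ccc3c(O)c([N+](=O)[O-])c(=O)oc3c2)cc1`, which has methoxy in place of methyl on a carbonyl carbon. The same difference reads as acetyl to methoxycarbonyl, or as 4-acetylphenyl to 4-(methoxycarbonyl)phenyl.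

Among the measured compounds shown here, the only measured step that bears on this change is a step that the limit leaves unreadable from compound 2 to compound 3, so it offers no size to carry over. It does show that the group at this place has already been exchanged once, though how much that exchange moved the read-out cannot be told. For the measured compounds named here, compound 1 offers no step at this place.

With no readable size to go on, the expectation rests on compound 3 at 6100 nM, and no shift beyond the scatter is expected in this assay, in either direction. The expected step is a 1.0-fold lower number from compound 3 to compound 4 (0.01 log units; within the scatter). Compound 4 is estimated at 6000 nM, with an expected range of 2500 nM to 15000 nM.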

Compound 4, half-maximal inhibitory concentration: > 10000 nM
Compound 4 ended at the assay's limit; the forecaster's own chance of this, stated with the estimate: 35%; middle value at least 1.6-fold (0.22 log units) away from the limit.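

In this assay, the exchange on the carbonyl carbon gives an at least 1.6-fold higher number from compound 3 to compound 4 (0.21 log units; that floor lies within the scatter), and since that floor lies within the scatter, the result does not by itself establish a real loss on going from acetyl to methoxycarbonyl; it shows only that methoxycarbonyl brought no lower number than acetyl. Compound 4 reads > 10000 nM, and the full size of the step stays unknown because this value is a limit of the assay and not a number: the limit of > 10000 nM in this assay, at which 1 of the 4 values shown sits. The steps that start from compound 2 cannot be read, and its comparison with compound 3 and compound 4 stays closed because its own reading is also a limit: the limit of > 4000 nM in this assay, at which 1 of the 4 values shown sits.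

Still open, as far as these compounds go, is how a carboxylic acid or an amine in place of the methoxycarbonyl on the 4-(methoxycarbonyl)phenyl group would read in this assay. Compound 1 differs from compound 3 and compound 4 in more than one place, so the compounds shown do not say which of those differences matters at this position.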